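This account rests on a few compounds, and the source may have more. Where it says the series, first, only, none or still open, it means among the compounds named here.

Working notes on a series of three measured compounds and one still open. In a physicochemical assay for lipophilicity (on this read-out higher numbers stand for higher lipophilicity and lower numbers for lower lipophilicity), compound 1 `COc1cc(/C=C2\CCC/C(=C\c3ccccc3[N+](=O)[O-])C2=O)cc(OC)c1OC` gives 4.86. Compound 2 `Cc1ccc(/C=C2\CCC/C(=C\c3ccccc3[N+](=O)[O-])C2=O)cc1` gives 4.86 in this assay, the same value as compound 1 at the digits shown; compound 3 `Cc1ccc(/C=C2\CCC/C(=C\c3ccc([N+](=O)[O-])cc3)C2=O)cc1` gives 5.08 in this assay, and all three values lie within the usual scatter of one another. Compound 4 `O=C1/C(=C/c2ccc(F)cc2)CCC/C1=C\c1ccccc1[N+](=O)[O-]` has not yet been measured. It differs from compound 2 by fluoro in place of methyl on an aromatic carbon. Among the measured compounds shown here, no measured pair shows this change, so the size of the step can only be expected, not read off. A modest fall in this assay, a number 0.41 log units lower from compound 2 to compound 4 (beyond the scatter), is expected. For compound 4 the estimate in this assay is 4.45, with a range from 4.15 to 4.75.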

Compound 4, partition coefficient: 4.86
Compound 4: middle estimate off by 0.41 log units, on the low side; the measured number lies above the stated range.
By their numbers in this assay, from the lowest: compounds 1, 2, 4 and 3 (each within the scatter of the next).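

Among the compounds shown here, the first single-place pair gives, in this assay, no change at the digits printed from compound 2 to compound 4 (within the scatter), for fluoro in place of methyl on an aromatic carbon, para to a large group. At this position, the read-out therefore does not separate 4-methylphenyl from 4-fluorophenyl, though this rests on one pair only. No measured property on hand accounts for this step. From the compounds shown here alone, whether other groups at this position, such as an amine or a carboxylic acid, would also leave the number in place remains open. So does whether this change behaves alike on the core of compound 3.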